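Working notes: bromo to hydroxy on compound 1

A few compounds are considered here, and "the series" means these few. Any claim that something is new, unique, unknown or untested is made for them only; others in the source may bear on it.

- compound 1 `O=S(=O)(/C=C/c1ccc(Br)cc1)Cc1ccc(Nc2ncnc3ccccc23)cc1`: > 100000 nM (a limit)
- compound 2 `CC(C)(C)c1cc(/C=C/S(=O)(=O)Cc2ccc(Nc3ncnc4ccccc34)cc2)cc(C(C)(C)C)c1O`: 6000 nM

In a functional assay on UACC-62 cells (Homo sapiens) (on this read-out lower numbers stand for stronger inhibition of growth and higher numbers for weaker inhibition of growth), compound 1 stands at the limit of > 100000 nM in this assay, at which 1 of the 2 values shown sits. This is a limit of the assay and not a number. Going by the values given here, compound 2 is the only compound here with a numerical value, and no step between measured compounds is available.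

Compound 3 `O=S(=O)(/C=C/c1ccc(O)cc1)Cc1ccc(Nc2ncnc3ccccc23)cc1` is still to be measured. It is derived from compound 1 by the change (hydroxy in place of bromo on an aromatic carbon), which puts hydroxy in place of bromo on an aromatic carbon. Compound 2 also carries a hydroxy group and gives 6000 nM, so a move toward stronger inhibition of growth is expected, though this rests on a single value. The expected change is an at least 5.0-fold lower number from compound 1 to compound 3 (0.69 log units; beyond the scatter), and its size is only loosely estimated. For compound 3 the estimated value is 20000 nM, with an expected range of 4000 nM to 100000 nM.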

Compound 3, concentration for 50% growth inhibition: 100000 nM
Estimate against measurement, compound 3: 5.0-fold (0.70 log units) below, and the stated range covers the measured number.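

In this assay compound 3 gives 100000 nM, which is a measured number for a 4-hydroxyphenyl at this position, where the 4-bromophenyl of compound 1 gave none. Compound 1 stands at a limit of the assay and not at a number: the limit of > 100000 nM in this assay, at which 1 of the 3 values shown sits. The step for hydroxy in place of bromo reads a number no higher from compound 1 to compound 3 (the limit leaves the size open) and the position shows as yet no measurable gain from this change.

An amine or a carboxylic acid in place of the hydroxy remains untested among the compounds shown, so it is open whether this position responds to any group on the ring. Also open is what the tert-butyl groups of compound 2 contribute, as no compound shown separates them from the hydroxy.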